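The compounds below may be only part of what the source reports. "The series", "measured", "known", "first", "only" and "open" are said of these compounds alone.

Compound 1 `CCCc1cnc(Nc2cc[nH]n2)n2c(CCC)nc(C)c12`: in a functional assay for inhibition, with Homo sapiens as the target (a higher number here means a weaker inhibitor, a lower number a stronger inhibitor), compound 1 gives > 48000 nM, which is a limit of the assay and not a number.
Compound 2 `Cc1ncn2c(Nc3cc[nH]n3)nccc12`: in this assay compound 2 gives 57000 nM.
Compound 3 `CCCc1nc(C)c2c(C)cnc(Nc3cc[nH]n3)n12`: in this assay compound 3 gives > 48000 nM, again a limit of the assay and not a number.

Compound 2 is therefore the only one of the three with a number; the other two sit at the limit described by the limit of > 48000 nM in this assay, at which 2 of the 3 values shown sit. Compound 3 and compound 1 share a core and differ in one place, (ethyl in place of hydrogen on a saturated chain carbon bound to an aromatic carbon), and the step in this assay from compound 3 to compound 1 is a step that the two limits leave unreadable from compound 3 to compound 1. Compound 4 `CCCc1ncn2c(Nc3cc[nH]n3)nccc12`, not yet measured, stands to compound 2 as compound 1 stands to compound 3: the change is ethyl in place of hydrogen on a saturated chain carbon bound to an aromatic carbon, the same kind of change at the same kind of place. The difference between the core of compound 2 and the core of compound 3 is not broken down here. The measured step gives no readable size, so the expectation for compound 4 rests on compound 2 alone, which gives 57000 nM. Compound 4 is expected to give about 50000 nM in this assay, within a range from 20000 nM to 150000 nM. The step from compound 2 to compound 4 is thus estimated at a 1.1-fold lower number from compound 2 to compound 4 (0.06 log units; within the scatter), a weak inhibitor either way.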

Compound 4, half-maximal inhibitory concentration: > 48000 nM
Compound 4 ended at the assay's limit; the forecaster's own chance of this, stated with the estimate: 45%; the middle value does not contradict the limit.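

In this assay compound 4 gives > 48000 nM, which is a limit of the assay and not a number. No new step can be read between compound 2 and compound 4. The compounds shown leave open what ethyl in place of hydrogen at this place does to inhibition, since only compound 2 has a number: the limit of > 48000 nM in this assay, at which 3 of the 4 values shown sit.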